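The compounds below may be only part of what the source reports. "The series", "measured", "known", "first", "only" and "open" are said of these compounds alone.

In a functional assay on HCT-116 cells (Homo sapiens) for antiproliferative activity, read by MTT assay, with a stated time of 48 h (on this read-out higher numbers stand for weaker inhibition and lower numbers for stronger inhibition), compound 1 `COc1cc(N(Cc2ccc(C)cc2)C(=O)CSc2nc3ccccc3s2)cc(OC)c1OC` gives > 80000 nM, which is a limit of the assay and not a number. Among the compounds with values here, compound 2 `COc1ccc(CN(C(=O)CSc2nc3ccccc3s2)c2cc(OC)c(OC)c(OC)c2)cc1F` gives 1830 nM, the only actual number so far.

Compound 3 `COc1ccc(CN(C(=O)CSc2nc3ccccc3s2)c2cc(OC)c(OC)c(OC)c2)cc1Br` keeps the rest of compound 2 and changes one substituent: bromo in place of fluoro on an aromatic carbon. This turns 3-fluoro-4-methoxybenzyl into 3-bromo-4-methoxybenzyl.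

Within the data shown here, the only measured step, an at least 43-fold lower number from compound 1 to compound 2 (1.64 log units; beyond the scatter), is large and bears on the same aromatic ring. However, it introduced the fluoro and methoxy groups together, so it does not isolate the halogen. It shows that this assay can respond strongly to changes on this ring, but it gives no direction for the swap of fluoro for bromo. A modest change of uncertain direction is therefore expected, with a wide margin.

The expected step is a 1.2-fold higher number from compound 2 to compound 3 (0.08 log units; within the scatter).

For compound 3, the estimated value is 2200 nM, with an expected range of 600 nM to 9000 nM.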

Compound 3, half-maximal inhibitory concentration: 4550 nM
For compound 3 the middle estimate is 2.1-fold (0.32 log units) below the measured one; the measured number falls inside the stated range.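

Taken alone, bromo in place of fluoro on an aromatic carbon gives a 2.5-fold higher number from compound 2 to compound 3 (0.40 log units; beyond the scatter) in this assay, so the halogen ortho to a methoxy group matters on its own, which the earlier step could not separate from the methoxy group. The large step from the 4-methylphenyl compound survives the swap, with an at least 17-fold lower number from compound 1 to compound 3 (1.24 log units; beyond the scatter), so it does not depend on fluoro specifically. Compound 1 gives a limit and not a number, so the true size of both large steps stays unknown: the limit of > 80000 nM in this assay, at which 1 of the 3 values shown sits.

From the compounds shown here alone, the share of the methoxy group in those large steps remains open, since both halogens appear only alongside it. Two halogens also give no trend, and chloro, hydroxyl or an amine at this carbon would show whether the preference for fluoro over bromo extends beyond this pair.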